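The source may report more compounds than this note shows. Statements on the series, on what has been measured and on what is new or still open speak of the compounds shown alone.

Measured compounds:
compound 1, `C=C1C[C@]23C[C@@]1(O)CC[C@H]2c1ccc(O)c(C)c1[C@@H]3Cn1cc(-c2ccccn2)nn1`: > 20000 nM
compound 2, `C=C1C[C@]23C[C@@]1(O)CC[C@H]2c1cc(Br)c(O)c(C)c1[C@@H]3Cn1cc(-c2ccc(Cl)cc2)nn1`: 18000 nM

In a functional assay on SW480 cells (Homo sapiens) for cytotoxicity, read by MTT assay, with a stated time of 4 days (on this read-out higher numbers stand for weaker inhibition and lower numbers for stronger inhibition), compound 1 gives > 20000 nM, which is a limit of the assay and not a number. For the measured compounds named here, compound 2 gives 18000 nM in this assay, the only number among the two values shown. Going by the values given here, compound 1 contributes only a limit, so no step between measured compounds can be stated. Among the compounds with values here, the pair therefore shows only that compound 2 reached a number while compound 1 did not, consistent with the limit of > 20000 nM in this assay, at which 1 of the 2 values shown sits.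

Compound 3, `C=C1C[C@]23C[C@@]1(O)CC[C@H]2c1ccc(O)c(C)c1[C@@H]3Cn1cc(-c2ccc(Cl)cc2)nn1`, is made from compound 2 by hydrogen in place of bromo on an aromatic carbon. Within the data shown here, with no measured step to guide the size of this change, compound 3 is expected to sit close to compound 2 within the scatter, or slightly weaker, so the step from compound 2 to compound 3 is estimated as a 1.4-fold higher number from compound 2 to compound 3 (0.14 log units; within the scatter). Compound 3 is estimated at 25000 nM in this assay, with a range from 10000 nM to 60000 nM, and a fair chance that only a limit is reported.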

Compound 3, half-maximal inhibitory concentration: > 20000 nM
Compound 3: no number, only a limit; the forecaster's own chance of this, stated with the estimate: 50%; the middle value does not contradict the limit.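

Hydrogen in place of bromo, on the aromatic carbon ortho to the hydroxy group, gives an at least 1.1-fold higher number from compound 2 to compound 3 (0.04 log units; that floor lies within the scatter) in this assay, so this change shows only a floor and not a measured loss of activity. Compound 3 gives only a limit, and the series now rests mostly at that same limit: the limit of > 20000 nM in this assay, at which 2 of the 3 values shown sit. Compound 1 and compound 3 both give limits, and the step between them, 4-chlorophenyl in place of pyridin-2-yl, cannot be read.

On these data alone, how far compound 3 truly lies from compound 2 remains open, so any real contribution of the bromo is still undefined. Also open, as far as these compounds go, is whether another group on this aromatic carbon, such as chloro or an amine, would give a number in this assay.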